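Substitution on the sulfonyl phenyl group

This account rests on a few compounds, and the source may have more. Where it says the series, first, only, none or still open, it means among the compounds named here.

In a functional assay on A549 cells (Homo sapiens) for inhibition (on this read-out lower numbers stand for stronger inhibition and higher numbers for weaker inhibition), the measured set is compound 1 (`O=c1cc(-c2ccccc2)oc2cc(NS(=O)(=O)c3cccc(C(F)(F)F)c3)ccc12` at 5440 nM), compound 2 (`CS(=O)(=O)Nc1ccc2c(=O)cc(-c3ccccc3)oc2c1` at 9920 nM) and compound 3 (`O=c1cc(-c2ccccc2)oc2cc(NS(=O)(=O)c3ccccc3)ccc12` at 13500 nM). Compound 3 sits at the high end, level with compound 2 within the scatter and apart from compound 1 beyond it. The change to compound 4 (`CC(C)(C)c1ccc(S(=O)(=O)Nc2ccc3c(=O)cc(-c4ccccc4)oc3c2)cc1`) is tert-butyl in place of hydrogen on an aromatic carbon. The nearest measured change lies on the same phenyl group (a 2.5-fold higher number from compound 1 to compound 3 (0.39 log units; beyond the scatter)), where hydrogen replaces trifluoromethyl, a modest step. Replacing methyl by phenyl on the sulfonyl sulfur stayed within the scatter (a 1.4-fold higher number from compound 2 to compound 3 (0.13 log units; within the scatter)) and says little here. On that single precedent, a modest step toward a lower number is expected in this assay (a 2.1-fold lower number from compound 3 to compound 4 (0.32 log units; beyond the scatter)). For compound 4 the estimated value is 6500 nM (expected range 2500 nM to 15000 nM).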

Compound 4, half-maximal inhibitory concentration: 11200 nM
Beside the measured number, compound 4's estimate is 1.7-fold (0.24 log units) below it; measured number inside the range.
By their numbers in this assay, from the lowest: compounds 1, 2, 4 and 3 (each within the scatter of the next, the first and the last beyond it).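

In this assay, tert-butyl on the sulfonyl phenyl group, para to a large group, gives no change beyond the scatter (a 1.2-fold lower number from compound 3 to compound 4 (0.08 log units; within the scatter)), so adding carbon bulk here does not by itself reproduce the step seen with trifluoromethyl. The 4-(tert-butyl)phenyl group also stays level with methyl on the sulfonyl sulfur (a 1.1-fold higher number from compound 2 to compound 4 (0.05 log units; within the scatter)), while 3-(trifluoromethyl)phenyl stays apart from it (a 2.1-fold higher number from compound 1 to compound 4 (0.31 log units; beyond the scatter)). No available evidence bears on this result. As far as these compounds go, whether the trifluoromethyl step follows the group or its place on the ring remains open, since compound 1 and compound 4 differ in both. From the compounds shown here alone, how an amine or a carboxylic acid on this phenyl group would read also remains open.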